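Aryl Variation at One Core Carbon: Compounds 1 to 4

The source may hold more compounds than are shown below. What is called first, only, known or untested is meant among the compounds shown, and "the series" means these compounds.

Measured so far:
Compound 1, `O=C(O)Cc1sc(C(c2ccc(F)cc2)c2ccc(F)cc2)nc1-c1ccnc(F)c1`, in an in vitro functional assay on HEK285-7 cells for antagonist activity at prostaglandin D2 receptor 2 (Homo sapiens), read by BRET and beta-arrestin recruitment (a lower number here means a smaller maximal response, a higher number a larger maximal response), compound 1 gives 80%.
Compound 2, `O=C(O)Cc1sc(C(c2ccc(F)cc2)c2ccc(F)cc2)nc1-c1ccccc1`, in this assay compound 2 gives 80%.
Compound 3, `O=C(O)Cc1sc(C(c2ccc(F)cc2)c2ccc(F)cc2)nc1-c1ccco1`, in this assay compound 3 gives 80%.

On the numbers shown compound 3 stands level with compound 1 and compound 2; the three values cannot be told apart at the digits reported. The three measured steps all exchange the aryl group on the same carbon of the shared core: no change at the digits printed from compound 1 to compound 2 (within the scatter), no change at the digits printed from compound 1 to compound 3 (within the scatter) and no change at the digits printed from compound 2 to compound 3 (within the scatter). None of them reaches beyond the scatter, so across a six-membered ring with one nitrogen bearing fluorine, a plain phenyl and a five-membered ring with one oxygen the largest response in this assay has not moved.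

Compound 4, `COc1cc(-c2nc(C(c3ccc(F)cc3)c3ccc(F)cc3)sc2CC(=O)O)ccn1`, is not yet measured. The change from compound 3 is 2-methoxypyridin-4-yl in place of furan-2-yl on an aromatic carbon.

All three measured steps bear directly on this exchange, since each replaced the group at the same carbon, and each was within the scatter. The 2-methoxypyridin-4-yl group is closest in kind to the 2-fluoropyridin-4-yl of compound 1, which gave 80%. The expected step is therefore no change at the digits printed from compound 3 to compound 4 (within the scatter), none beyond the scatter. For compound 4 in this assay the estimate is 80%, with a range from 70% to 90%.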

Compound 4, largest response reached (reported as efficacy), in percent of the reference or control that the assay uses: 60%
Compound 4: middle estimate off by 20 percentage points, on the high side; measured number below the stated range.
By their numbers in this assay, from the lowest: compound 4; then compounds 1, 2 and 3 (each within the scatter of the next).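

In this assay this position is not indifferent to the group it carries: 2-methoxypyridin-4-yl gives a number 20 percentage points lower from compound 3 to compound 4 (beyond the scatter) and a number 20 percentage points lower from compound 2 to compound 4 (beyond the scatter) while furan-2-yl, phenyl and 2-fluoropyridin-4-yl stay within the scatter of one another. The closest comparison changes only the substituent on the six-membered aromatic ring, with methoxy in place of fluoro giving a number 20 percentage points lower from compound 1 to compound 4 (beyond the scatter) and leaving the rest of the structure untouched, so that ring alone does not go with the lower number, as compound 1 carries it and stands level with compounds 2 and 3. The compounds shown offer no measurement that accounts for this difference in maximal response.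

Open, on these data alone, is whether the lower number follows the methoxy group as a whole or only its oxygen or its methyl, which hydroxy, ethoxy, methyl or dimethylamino at the same ring carbon would begin to separate. Also open, as far as these compounds go, is whether the same step appears without the ring nitrogen, as a 3-methoxyphenyl group on this core would show.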